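Swapping trifluoromethyl for methoxy on the benzyl ring

A few compounds are considered here, and "the series" means these few. Any claim that something is new, unique, unknown or untested is made for them only; others in the source may bear on it.

Measured compounds:
compound 1 `O=C(CCC1=CCN(Cc2ccc(C(F)(F)F)cc2)C1=O)NO` gives 4540 nM
compound 2 `O=C(CCC1=CCN(Cc2cccc(C(F)(F)F)c2)C1=O)NO` gives 540 nM
compound 3 `COc1cccc(CCCN2CC=C(CCC(=O)NO)C2=O)c1` gives > 10000 nM

These three share a core carrying a hydroxamic acid chain, and they were tested in a functional assay on HCT-15 cells (Homo sapiens) for antiproliferative activity; a higher number here means a weaker inhibitor of growth, a lower number a stronger inhibitor of growth. Compound 1 holds the highest of the two numbers that were read as numbers; the nearest is compound 2, which sits well below it, a gap beyond the usual scatter. For compound 3 the result is a limit rather than a number, namely (the limit of > 10000 nM in this assay, at which 1 of the 3 values shown sits).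

Compound 4 `COc1ccc(CN2CC=C(CCC(=O)NO)C2=O)cc1` has not yet been measured. It differs from compound 1 in one spot: methoxy in place of trifluoromethyl on an aromatic carbon. Among the compounds with values here, no measured pair in this set follows that same change, so its size cannot be read off directly. Within the data shown here, since compound 1 already stands weak and compound 3, the only methoxy-bearing compound here, reached only a limit, the expected step of a 1.8-fold higher number from compound 1 to compound 4 (0.25 log units; within the scatter) is a modest move toward weaker growth inhibition, possibly within the scatter. Compound 4 is therefore estimated at 8000 nM, with a plausible range from 2500 nM to 25000 nM.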

Compound 4, concentration for 50% growth inhibition: 1720 nM
Compound 4: middle estimate off by 4.7-fold (0.67 log units), on the high side; measured number outside the range, below it.
By their numbers in this assay, from the lowest: compound 2; then compound 4; then compound 1. At a limit, above all of these: compound 3.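

At this spot, on an aromatic carbon para to a large group, methoxy in place of trifluoromethyl gives a 2.6-fold lower number from compound 1 to compound 4 (0.42 log units; beyond the scatter) in this assay, so this swap strengthens growth inhibition. Within the data shown here, it is the first step in the set between two compounds that differ in only one place, and it shows that trifluoromethyl is not required here for growth inhibition, since a group with fewer heavy atoms and one hydrogen-bond acceptor does better. Nothing measured here bears on why this swap has this effect.

From the compounds shown here alone, a single step sets no trend, so it remains open whether a nitrile, an amine or a carboxylic acid on the same carbon would do better or worse. Going by these compounds, it also remains open how methoxy would fare on the ring carbon that carries trifluoromethyl in compound 2.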